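Trifluoroethoxycarbonyl tail on the shared core: cytotoxicity notes

The compounds below may be only part of what the source reports. "The series", "measured", "known", "first", "only" and "open" are said of these compounds alone.

Compound 1 `COc1ccc(C(=O)Nc2cc3nc(C4CCCCC4)[nH]c3cc2N2CCCC2)cc1` carries a 4-methoxyphenyl group on the carbonyl carbon. In an ADME assay on Vero cells (Chlorocebus sabaeus) for cytotoxicity, read by resazurin assay, with a stated time of 3 days (on this read-out lower numbers stand for stronger inhibition and higher numbers for weaker inhibition), compound 1 gives > 100 ug/mL, which is a limit of the assay and not a number. Compound 2 `Cc1ccc(C(=O)Nc2cc3nc(C4CCCCC4)[nH]c3cc2N2CCCC2)cc1` has methyl in place of methoxy on an aromatic carbon; in this assay compound 2 gives > 100 ug/mL, again a limit. Compound 3 `COCCOC(=O)Nc1cc2nc(C3CCCCC3)[nH]c2cc1N1CCCC1` bears 2-methoxyethoxy on the carbonyl carbon, and in this assay compound 3 gives > 100 ug/mL, also a limit. Compound 3 therefore stands with the other two at the limit of > 100 ug/mL in this assay, at which 3 of the 3 values shown sit. The steps a step that the two limits leave unreadable from compound 1 to compound 2, a step that the two limits leave unreadable from compound 1 to compound 3 and a step that the two limits leave unreadable from compound 2 to compound 3 are all unreadable for this reason.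

Compound 4 `O=C(Nc1cc2nc(C3CCCCC3)[nH]c2cc1N1CCCC1)OCC(F)(F)F` differs from compound 3 by trifluoromethyl in place of methoxymethyl on a saturated chain carbon bound to an oxygen next to a carbonyl group. Among the measured compounds shown here, no measured step gives a readable size, so no direction can be taken from the series. The step from compound 3 to compound 4 in this assay is expected to be a step that the limit leaves unreadable from compound 3 to compound 4, that is, no change that would be read beyond the scatter. For compound 4 the value in this assay is estimated at 120 ug/mL, within a range of 60 ug/mL to 250 ug/mL, most likely reported again as a limit.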

Compound 4, half-maximal inhibitory concentration: > 100 ug/mL
Compound 4: a limit, no number; the forecaster's own chance of this, stated with the estimate: 70%; the middle value lies beyond the limit too.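

In this assay compound 4 gives > 100 ug/mL as a limit and not a number, so no step from compound 1, compound 2 or compound 3 to compound 4 can be read: the limit of > 100 ug/mL in this assay, at which 4 of the 4 values shown sit.

The compounds shown leave open whether any group on the carbonyl carbon changes the cytotoxicity of the shared core.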